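Methoxy to Nitro: Expected Change in Rat Toxicity

The source may report more compounds than this note shows. Statements on the series, on what has been measured and on what is new or still open speak of the compounds shown alone.

The measured compounds and their values in a toxicity assay on the whole organism with Rattus norvegicus as the target, at a dose of 200 mg/kg by the oral route; on this read-out lower numbers stand for a weaker effect and higher numbers for a stronger effect at the one dose given:
compound 1, `COc1ccc(OCC2=NCCO2)cc1`, 70%
compound 2, `Clc1ccccc1OCC1=NCCO1`, 40%
compound 3, `O=[N+]([O-])c1ccccc1OCC1=NCCO1`, 55%

Compound 1 stands highest of the three in this assay, beyond the scatter above both compound 3 and compound 2. The unmeasured compound 4, `O=[N+]([O-])c1ccc(OCC2=NCCO2)cc1`, differs from compound 1 by nitro in place of methoxy on an aromatic carbon. Among the compounds with values here, the one measured step with a nitro entering, a number 15 percentage points higher from compound 2 to compound 3 (beyond the scatter), replaced chloro rather than methoxy, so it bears only loosely on this change; no pair directly shows methoxy against nitro. Compound 4 is therefore expected to stay close to compound 1, with a step of a number 5 percentage points lower from compound 1 to compound 4 (within the scatter) not clearly beyond the scatter. Compound 4 is estimated at 65%, ranging from 45% to 85%.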

Compound 4, a percentage reported as activity, at one dose (the size of the read-out at that dose, not a potency): 70%
Compound 4: middle estimate off by 5 percentage points, on the low side, within the range that was stated.
By their numbers in this assay, from the lowest: compound 2; then compound 3; then compounds 1 and 4 (each within the scatter of the next).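

In this assay, nitro in place of methoxy on an aromatic carbon, para to a group of 7 heavy atoms, gives no change at the digits printed from compound 1 to compound 4 (within the scatter). Within the data shown here, this is the first direct comparison of these two groups, and it shows that they can be exchanged at this position without a step beyond the scatter, whereas the only earlier step with nitro entering replaced chloro and gave a number 15 percentage points higher from compound 2 to compound 3 (beyond the scatter). Nothing available here accounts for this result.

On these data alone, whether an amine or a carboxylic acid on this same aromatic carbon would move the read-out stays open. So does whether chloro there would sit with methoxy and nitro.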